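Chloro to propyl on the aromatic ring

The source may report more compounds than this note shows. Statements on the series, on what has been measured and on what is new or still open speak of the compounds shown alone.

Going by the values given here, in a functional assay on HT-29 cells (Homo sapiens) for antiproliferative activity, read by MTT assay, with a stated time of 96 h (a lower number here means a stronger inhibitor, a higher number a weaker inhibitor), compound 1 `O=C1C2=C(C(=O)c3ncccc31)C1(CS2)NC(=O)N(c2ccc(Cl)cc2)C1=O` gives 2 nM, its only single number, and a further entry carries none. Compound 2 `O=C1NNC(=O)C2(CSC3=C2C(=O)c2ncccc2C3=O)N1` gives the much higher 1580 nM; 1600 nM; 1600 nM (3 entries). Compound 3 `CCCc1ccc(N2C(=O)NC3(CSC4=C3C(=O)c3ncccc3C4=O)C2=O)cc1` keeps the core of compound 1 and changes one place: propyl in place of chloro on an aromatic carbon, 4-chlorophenyl to 4-propylphenyl. Among the compounds with values here, no measured step covers this change, so the expectation rests on compound 1 alone, at 2 nM. A small loss of strength in this assay is expected, with the estimated 2.5-fold higher number from compound 1 to compound 3 (0.40 log units; beyond the scatter) not far beyond the scatter. Compound 3 is estimated at 5 nM, within a range of 1 nM to 30 nM.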

Compound 3, half-maximal inhibitory concentration: 1 nM
The estimate for compound 3 lay 5.0-fold (0.70 log units) above the measured number; measured number inside the range.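

In this assay the exchange of chloro for propyl gives a 2.0-fold lower number from compound 1 to compound 3 (0.30 log units; within the scatter) and so leaves the strength of the series unchanged. This position on the aromatic ring, para to a large group, therefore accepts propyl with 3 heavy atoms in place of chloro with 1 heavy atom, without a measurable loss. Nothing shown accounts for this tolerance.

As far as these compounds go, whether it extends to a longer chain such as hexyl, or to an amine or a carboxylic acid at this position, remains open. From the compounds shown here alone, whether other places on the aromatic ring behave alike also remains open.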